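The source may hold more compounds than are shown below. What is called first, only, known or untested is meant among the compounds shown, and "the series" means these compounds.

Four compounds share one core, in which an amide-bearing phenyl ether is joined to a bromo-substituted pyrimidine that carries an aryl amine. In a functional assay on U-937 cells (Homo sapiens) for antiproliferative activity, read by MTT assay, with a stated time of 24 h (on this read-out higher numbers stand for weaker inhibition and lower numbers for stronger inhibition), compound 1 `CNC(=O)c1ccccc1Oc1nc(Nc2cccc(Br)c2)ncc1Br` gives 49000 nM. Compound 2 `CNC(=O)c1ccccc1Oc1nc(Nc2cccc(C)c2)ncc1Br` gives 15900 nM in this assay. Among the compounds with values here, compound 3 `CNC(=O)c1ccccc1Oc1nc(Nc2ccc(Cl)cc2F)ncc1Br` returns only a limit of the assay, > 50000 nM, so its position is known just as a floor, and it is the one compound in this set that sits at the limit described by the limit of > 50000 nM in this assay, at which 1 of the 3 values shown sits.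

Two steps among the measured compounds matter. The exchange of bromo for methyl on the aromatic carbon gave a 3.1-fold lower number from compound 1 to compound 2 (0.49 log units; beyond the scatter). Replacing 3-methylphenyl by 4-chloro-2-fluorophenyl on the nitrogen gave an at least 3.1-fold higher number from compound 2 to compound 3 (0.49 log units; beyond the scatter). Compound 4 `CNC(=O)c1ccccc1Oc1nc(Nc2cccc(C(C)C)c2)ncc1Br` reverses the second kind of change: 3-isopropylphenyl in place of 4-chloro-2-fluorophenyl on a nitrogen on an aromatic ring. Since compound 2, with its 3-methylphenyl group, gave a measured number of 15900 nM, an aryl ring carrying a small alkyl group on that nitrogen is expected to bring the number back down into the measured range, and the step from compound 3 to compound 4 is estimated as an at least 4.1-fold lower number from compound 3 to compound 4 (0.61 log units; beyond the scatter). Compound 4 is therefore expected to give about 12000 nM in this assay, plausibly between 4000 nM and 40000 nM.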

Compound 4, half-maximal inhibitory concentration: 14100 nM
Compound 4: the middle estimate sits 1.2-fold (0.07 log units) below what was measured; low and high end bracket the measured number.
By their numbers in this assay, from the lowest: compounds 4 and 2 (each within the scatter of the next); then compound 1. At a limit, above all of these: compound 3.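

On the nitrogen, 3-isopropylphenyl in place of 4-chloro-2-fluorophenyl gives an at least 3.5-fold lower number from compound 3 to compound 4 (0.54 log units; beyond the scatter) in this assay, which places a second alkyl-bearing aryl ring in the measured range alongside the 3-methylphenyl of compound 2. On the aromatic carbon of that ring, isopropyl in place of methyl gives a 1.1-fold lower number from compound 2 to compound 4 (0.05 log units; within the scatter), while isopropyl in place of bromo gives a 3.5-fold lower number from compound 1 to compound 4 (0.54 log units; beyond the scatter), so at this position the two alkyl groups read alike and both stand apart from bromo. Compound 3 is known only through a limit of the assay, so the first of these steps is a floor rather than a measured size: the limit of > 50000 nM in this assay, at which 1 of the 4 values shown sits.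

The compounds shown leave open whether the likeness of methyl and isopropyl carries over to a longer chain such as n-butyl, or whether an amine or a carboxylic acid at the same place would read differently. Also open, as far as these compounds go, is whether the chloro group, the fluoro group or both together set compound 3 apart from the alkyl-bearing compounds.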